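Lengthening the amine substituent on a benzylamine side chain

The source may report more compounds than this note shows. Statements on the series, on what has been measured and on what is new or still open speak of the compounds shown alone.

Three compounds share one core, a bicyclic carbonyl-bearing ring system carrying two methoxy groups, linked through a saturated chain to a tertiary amine that also bears a benzyl group. Compound 1 `COc1ccccc1CN(C)CCCCn1sc2cc(OC)c(OC)cc2c1=O` has a short chain and an extra methoxy on its benzyl ring; in an assay on isolated protein for inhibition of Amine oxidase [flavin-containing] A (Homo sapiens), read by fluorescence, with a stated time of 30 min (on this read-out higher numbers stand for weaker inhibition and lower numbers for stronger inhibition), compound 1 gives 7100 nM. Compound 2 `CCN(CCCCn1sc2cc(OC)c(OC)cc2c1=O)Cc1ccc(N(C)C)cc1` carries an ethyl on the amine and a dimethylamino group on its benzyl ring, and in this assay compound 2 gives 15900 nM. Compound 3 `COc1cc2sn(CCCCCCN(C)Cc3ccccc3)c(=O)c2cc1OC` has the longest chain and a methyl on the amine; in this assay compound 3 gives 23000 nM. Among these three numbers compound 3 shows the highest; its gap to compound 2 lies within the scatter, while compound 1 stands beyond the scatter below it.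

Compound 4 `CCN(CCCCCCn1sc2cc(OC)c(OC)cc2c1=O)Cc1ccccc1` differs from compound 3 only by methyl in place of hydrogen on a saturated chain carbon bound to an amine nitrogen. Within the data shown here, no measured pair here isolates that change. Because compound 3 gives 23000 nM and the change is small, the step from compound 3 to compound 4 is expected to be a 1.0-fold higher number from compound 3 to compound 4 (0.02 log units; within the scatter), no larger than the scatter. Compound 4 is therefore estimated at 24000 nM, likely between 9000 nM and 60000 nM.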

Compound 4, half-maximal inhibitory concentration: 8200 nM
Estimate against measurement, compound 4: 2.9-fold (0.47 log units) above; the whole stated range lies above it.
By their numbers in this assay, from the lowest: compounds 1, 4, 2 and 3 (each within the scatter of the next, the first and the last beyond it).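

In this assay, methyl in place of hydrogen on a saturated chain carbon bound to an amine nitrogen gives a 2.8-fold lower number from compound 3 to compound 4 (0.45 log units; beyond the scatter), a modest step toward stronger inhibition that lies beyond the usual scatter. So at this place, a single added carbon, which turns the methyl on the amine into an ethyl, is enough to change the read-out. The earlier compounds could not show this, as each differs from the others in more than one place, and nothing measured here explains the shift.

As far as these compounds go, it remains open whether a propyl or a cyclopropyl on the same amine nitrogen would lower the number further or raise it again. From the compounds shown here alone, it is also open whether the change from methyl to ethyl gives a similar step on the shorter chain of compound 1.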